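Amino in place of hydroxy two bonds from sulfur

The source may report more compounds than this note shows. Statements on the series, on what has been measured and on what is new or still open speak of the compounds shown alone.

Three compounds share one core and differ only in the group carried on the saturated chain carbon bound to a sulfur. Compound 1 `C=CCSS[C@H]1C[C@H](n2cc(C)c(=O)[nH]c2=O)O[C@@H]1CO` carries a vinyl there; in a physicochemical assay for metabolic stability, in the presence of a further agent that is not named here (on this read-out lower numbers stand for a shorter-lived compound and higher numbers for a longer-lived compound), compound 1 gives only a limit, < 8 h. Compound 2 `CCCCCCSS[C@H]1C[C@H](n2cc(C)c(=O)[nH]c2=O)O[C@@H]1CO` carries a pentyl in its place; in this assay compound 2 likewise gives only a limit, < 8 h. Compound 3 `Cc1cn([C@H]2C[C@H](SSCCO)[C@@H](CO)O2)c(=O)[nH]c1=O` carries a hydroxymethyl; in this assay compound 3 stands at a limit as well, < 8 h. The steps a step that the two limits leave unreadable from compound 1 to compound 2, a step that the two limits leave unreadable from compound 1 to compound 3 and a step that the two limits leave unreadable from compound 2 to compound 3 cannot be read in size because of the limit of < 8 h in this assay, at which 3 of the 3 values shown sit. Compound 3 thus stands where every measured value stands, at a limit and not at a number.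

Compound 4 `Cc1cn([C@H]2C[C@H](SSCCN)[C@@H](CO)O2)c(=O)[nH]c1=O` differs from compound 3 in one place: amino in place of hydroxy on a saturated chain carbon, two bonds along the chain from a sulfur. Going by the values given here, none of the measured steps can say how large a change this brings in this assay, nor in which direction. Compound 4 is expected to give 4 h in this assay, with a range from 1 h to 12 h. The step this estimate means is expected to be a step that the limit leaves unreadable from compound 3 to compound 4.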

Compound 4, half-life: < 8 h
Compound 4: only a limit was reported; the forecaster's own chance of this, stated with the estimate: 80%; the middle value lies beyond the limit too.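

Going by these compounds alone, no step from compound 1, compound 2 or compound 3 to compound 4 can be read in size in this assay because the values stop at a limit: the limit of < 8 h in this assay, at which 4 of the 4 values shown sit. The compounds shown leave open the actual half-life of each compound, and whether amino or hydroxy gives the longer one.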